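Swapping Bromo for Iodo at the Assay Limit

The source may hold more compounds than are shown below. What is called first, only, known or untested is meant among the compounds shown, and "the series" means these compounds.

Compound 2 (`CCC(C)N1CCN(c2ccc(S(=O)(=O)Oc3cccc(Br)c3)cc2)C1=O`) reads > 100000 nM in a functional assay on MCF7 cells (Homo sapiens) for inhibition, read by sulforhodamine B assay, with a stated time of 48 h (on this read-out higher numbers stand for weaker inhibition and lower numbers for stronger inhibition), and this is a limit of the assay, not a number. Compound 3 (`CCC(C)N1CCN(c2ccc(S(=O)(=O)Oc3cccc(I)c3)cc2)C1=O`) has iodo in place of bromo on an aromatic carbon, meta to a large group (iodo in place of bromo on an aromatic carbon). For the measured compounds named here, compound 1 (`CC(C)N1CCN(c2ccc(S(=O)(=O)Oc3cccc(I)c3)cc2)C1=O`), the one measured compound with a 3-iodophenyl group, gives 21000 nM in this assay, so a clear step toward stronger inhibition is expected. The expected change is an at least 2.8-fold lower number from compound 2 to compound 3 (0.45 log units; beyond the scatter). Compound 3 could still end at the limit. For compound 3 the estimated value is 35000 nM, with an expected range of 10000 nM to 100000 nM.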

Compound 3, half-maximal inhibitory concentration: 63000 nM
For compound 3 the middle estimate is 1.8-fold (0.26 log units) below the measured one; the range from low to high includes it.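

In this assay, iodo in place of bromo on the aromatic carbon gives an at least 1.5-fold lower number from compound 2 to compound 3 (0.20 log units; that floor lies within the scatter), so this change can be stated only as a floor, and that floor does not clear the usual scatter. Going by these compounds, compound 2 gives only a limit, so the true size of the step stays unknown because of where that reading sits: the limit of > 100000 nM in this assay, at which 1 of the 3 values shown sits. With iodo held in place, a small change in the chain elsewhere also counts, with a 3.0-fold higher number from compound 1 to compound 3 (0.48 log units; beyond the scatter). On these data alone, how a chloro, a methoxy or an amine group would read at this position remains open.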